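Replacing the Pyridine Tail with an Aminophenyl Group

The source may report more compounds than this note shows. Statements on the series, on what has been measured and on what is new or still open speak of the compounds shown alone.

Within the data shown here, compound 3 `O=C(CCCCCCc1cccnc1)c1ncc(-c2ccccn2)o1` gives 32 nM in an assay for inhibition of Fatty-acid amide hydrolase 1 (Rattus norvegicus) (on this read-out higher numbers stand for weaker inhibition and lower numbers for stronger inhibition), the lowest of the three numbers measured so far. Compound 2 `O=C(CCCCC#Cc1ccncc1)c1ncc(-c2ccccn2)o1` gives 150 nM in this assay, and compound 1 `O=C(CCCCC#Cc1cccnc1)c1ncc(-c2ccccn2)o1` gives 300 nM. The two steps leading to compound 3 are a 9.4-fold lower number from compound 1 to compound 3 (0.97 log units; beyond the scatter) and a 4.7-fold lower number from compound 2 to compound 3 (0.67 log units; beyond the scatter), both beyond the scatter, whereas the step of a 2.0-fold lower number from compound 1 to compound 2 (0.30 log units; within the scatter) stays within it.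

Compound 4 `Nc1cccc(CCCCCCC(=O)c2ncc(-c3ccccn3)o2)c1` differs from compound 3 by 3-aminophenyl in place of pyridin-3-yl on a saturated chain carbon, six bonds along the chain from a carbonyl carbon. Among the measured compounds shown here, no measured step exchanges the tail ring while the saturated chain is kept, so the bearing of the earlier steps is indirect. For the measured compounds named here, the only step that touches the tail ring at all is a 2.0-fold lower number from compound 1 to compound 2 (0.30 log units; within the scatter), which was within the scatter, and the larger steps concerned the chain, which compound 4 keeps unchanged from compound 3. On this basis no step beyond the scatter is expected in this assay, in either direction, though the range is kept wide to reflect the missing comparison.

Compound 4 is therefore estimated to give 35 nM in this assay, with a range from 10 nM to 120 nM. The step this estimate implies, a 1.1-fold higher number from compound 3 to compound 4 (0.04 log units; within the scatter), is expected to lie within the scatter.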

Compound 4, inhibition constant: 30 nM
Compound 4: middle estimate off by 1.2-fold (0.07 log units), on the high side; low and high end bracket the measured number.
By their numbers in this assay, from the lowest: compounds 4 and 3 (each within the scatter of the next); then compounds 2 and 1 (each within the scatter of the next).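

In this assay, among these compounds, the exchange of pyridin-3-yl for 3-aminophenyl gives a 1.1-fold lower number from compound 3 to compound 4 (0.03 log units; within the scatter) and is the first comparison in which the tail ring changes while the saturated chain stays the same. The place six bonds along the chain from a carbonyl carbon therefore accepts a ring of carbon only in place of a ring with a hetero atom, and a tail with a hydrogen-bond donor in place of one without, with no step beyond the scatter. The ring nitrogen of pyridin-3-yl is thus not needed at this place to keep the number in the range of compound 3, and no supporting evidence is available to explain why the two tails read alike.

From the compounds shown here alone, it remains open whether a plain phenyl, 3-hydroxyphenyl, 3-carboxyphenyl or 4-aminophenyl tail at this place would also stay within the scatter of 3-aminophenyl. Going by these compounds, it is also open whether the same exchange would hold on a longer chain or on the triple-bonded chain of compound 1.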